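The source may hold more compounds than are shown below. What is called first, only, known or untested is meant among the compounds shown, and "the series" means these compounds.

Three close analogues of one sulfonamide series have been run in an assay on isolated protein for inhibition of malate dehydrogenase, mitochondrial (Sus scrofa), with stated times of 45 min and 30 min (a lower number here means a stronger inhibitor, a higher number a weaker inhibitor), and none of them has given a number. Compound 1 `O=S(=O)(Nc1ccc(-c2nc3ccccc3o2)cc1)c1cccs1` reaches only the assay limit of > 63000 nM. Compound 2 `COc1cccc(S(=O)(=O)Nc2ccc3oc(-c4ccccc4)nc3c2)c1` likewise stops at the limit of > 63000 nM. Compound 3 `O=S(=O)(Nc1ccc(-c2nc3ccccc3o2)cc1)c1ccccc1F` too is reported only as the limit of > 63000 nM. For the measured compounds named here, the one single-point change among the measured compounds, a step that the two limits leave unreadable from compound 1 to compound 3, therefore cannot be sized, as both ends of it sit at the limit; all that can be said is that (the limit of > 63000 nM in this assay, at which 3 of the 3 values shown sit).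

Compound 4 `COc1ccc(Cl)cc1S(=O)(=O)Nc1ccc2oc(-c3ccccc3)nc2c1` is the next member to be measured in this assay. It differs from compound 2 in one place: 5-chloro-2-methoxyphenyl in place of 3-methoxyphenyl on a sulfonyl sulfur. Going by the values given here, no measured step bears directly on this change, since the only step available, from compound 1 to compound 3, is unreadable, and compound 2 itself stands only at the limit. The expectation for compound 4 is thus that the step that the limit leaves unreadable from compound 2 to compound 4 brings no shift beyond the scatter, and that compound 4 again ends at the limit. The estimate for compound 4 in this assay is 100000 nM, with a range from 40000 nM to 400000 nM.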

Compound 4, half-maximal inhibitory concentration: > 63000 nM
Compound 4 was reported as a limit; the forecaster's own chance of this, stated with the estimate: 85%; the middle value does not contradict the limit.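

In this assay compound 4 gives > 63000 nM as a limit. For the compounds shown here, compound 2 also stands at a limit, so no step from compound 2 to compound 4 can be read. The compounds shown leave open whether any member of this series inhibits the enzyme measurably, and which change on the sulfonyl sulfur might alter that.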